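This account rests on a few compounds, and the source may have more. Where it says the series, first, only, none or still open, it means among the compounds named here.

Measured so far:
compound 1 `CCc1cc(C(C)=O)c(O)cc1OCCCCC#N` — 57%
compound 2 `CCCc1cc(C(C)=O)c(O)cc1OCCCCC#N` — 37%
compound 3 `CC(=O)c1cc(CC2CO2)c(OCCCCC#N)cc1O` — 24%

In an assay on isolated protein for binding affinity to leukotriene B4 receptor 1 (Homo sapiens), tested at 1 uM (a lower number here means less inhibition, a higher number more inhibition at the concentration tested (going by the name of the read-out)), compound 1 stands highest of the three, with compound 2 nearest and compound 3 furthest. The two steps away from it are a number 20 percentage points lower from compound 1 to compound 2 (beyond the scatter) and a number 33 percentage points lower from compound 1 to compound 3 (beyond the scatter); between the other two, a number 13 percentage points lower from compound 2 to compound 3 (beyond the scatter). All three measured steps alter the group on the saturated chain carbon bound to the aromatic carbon, and all lower the read-out.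

Compound 4 `CCc1cc(C(C)=O)c(O)cc1OCCCCCCC#N` is not yet measured. It differs from compound 1 in another place: 2-cyanoethyl in place of cyano on a saturated chain carbon, four bonds along the chain from an oxygen on an aromatic ring. Within the data shown here, none of the measured steps touches this chain, so no step bears directly on it; the measured compounds all carry the shorter chain that ends in cyano. With no guide of this kind, the expectation for compound 4 in this assay is a step of about a number 7 percentage points lower from compound 1 to compound 4 (within the scatter), which is not beyond the scatter. Compound 4 is therefore estimated at 50%, with a range from 28% to 70%.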

Compound 4, a percentage reported as inhibition, at one concentration (the size of the read-out at that concentration, not a potency): 73%
The estimate for compound 4 lay 23 percentage points below the measured number; measured number above the stated range.
By their numbers in this assay, from the lowest: compound 3; then compound 2; then compound 1; then compound 4.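

Replacing cyano with 2-cyanoethyl, on a saturated chain carbon four bonds along the chain from an oxygen on an aromatic ring, gives in this assay a number 16 percentage points higher from compound 1 to compound 4 (beyond the scatter). This is the only step shown at this position and the only one that raises the read-out, whereas the three earlier steps, all at the saturated chain carbon bound to the aromatic carbon, lower it. No measurement on hand accounts for the rise.

Open, going by these compounds, is whether the read-out keeps rising with a longer chain, such as 5-cyanopentyl in place of 3-cyanopropyl, or holds when a carboxylic acid or an amine replaces the nitrile. Also open, on these data alone, is whether the longer chain gives a similar step on compound 2 or compound 3.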